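Dioxopyrrolidinyl in place of chloromethylcarbonylamino on the shared core

The compounds below may be only part of what the source reports. "The series", "measured", "known", "first", "only" and "open" are said of these compounds alone.

Measured so far:
compound 1 `CC(=O)NC1=C(C#N)C(c2ccc(F)cc2)C2=C(CC(C)(C)CC2=O)N1c1ccc(S(N)(=O)=O)cc1`, 85900 nM
compound 2 `CC1(C)CC(=O)C2=C(C1)N(c1ccc(S(N)(=O)=O)cc1)C(NC(=O)CCl)=C(C#N)C2c1ccc(F)cc1`, 70800 nM

Both numbers come from a functional assay on MCF7 cells (Homo sapiens) for cytotoxicity, read by sulforhodamine B assay, with a stated time of 48 h; on this read-out lower numbers stand for stronger inhibition and higher numbers for weaker inhibition. Going by the values given here, compound 2 holds the lowest of the two numbers, but the only measured step, a 1.2-fold lower number from compound 1 to compound 2 (0.08 log units; within the scatter), is within the scatter, so no order between compound 1 and compound 2 can be read from it.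

The next compound, compound 3 `CC1(C)CC(=O)C2=C(C1)N(c1ccc(S(N)(=O)=O)cc1)C(N1C(=O)CCC1=O)=C(C#N)C2c1ccc(F)cc1`, is not yet measured. It differs from compound 2 in one place: 2,5-dioxopyrrolidin-1-yl in place of ((chloromethyl)carbonyl)amino on a double-bonded ring carbon. No measured step bears directly on this change; the one step shown, from compound 1 to compound 2, touched only the saturated chain carbon bound to the carbonyl carbon and was small. Among the compounds with values here, the change to compound 3 is larger, removing the hydrogen-bond donor and closing a ring, but the series gives no step of that kind to lean on. The expectation is therefore the neutral one: for compound 3 the estimated step is a 1.0-fold lower number from compound 2 to compound 3 (0.00 log units; within the scatter), with a wide range to allow for the untested change. Compound 3 is estimated at 70000 nM in this assay, between 25000 nM and 200000 nM.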

Compound 3, half-maximal inhibitory concentration: 94100 nM
The estimate for compound 3 lay 1.3-fold (0.13 log units) below the measured number, and the stated range covers the measured number.
By their numbers in this assay, from the lowest: compounds 2, 1 and 3 (each within the scatter of the next).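

In this assay, 2,5-dioxopyrrolidin-1-yl in place of ((chloromethyl)carbonyl)amino gives a 1.3-fold higher number from compound 2 to compound 3 (0.12 log units; within the scatter), and the same group in place of acetamido gives a 1.1-fold higher number from compound 1 to compound 3 (0.04 log units; within the scatter). The earlier step changed only the chain of the amide, whereas these steps replace the whole group on the double-bonded ring carbon: the entering group has a five-membered non-aromatic ring and 0 hydrogen-bond donors, yet its number stays within the scatter of both open-chain groups. In this small set, neither the loss of the amide hydrogen nor the closed ring separates the number for compound 3 from the other two, and no measurement at hand offers an explanation for this.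

The compounds shown leave open whether any group at this carbon can move the number beyond the scatter, for example a free amine, a carboxylic acid or a longer chain. They also leave open whether the same flat result would hold if the 4-fluorophenyl or 4-sulfamoylphenyl group were replaced, since both are common to compound 1, compound 2 and compound 3.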